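From an Inactive Fluorophenyl Analogue to a Pyrrolidinyl Replacement

A few compounds are considered here, and "the series" means these few. Any claim that something is new, unique, unknown or untested is made for them only; others in the source may bear on it.

Compound 1 `COc1ccc(-c2noc(-c3ccc(Cl)cc3)n2)cc1OC1CCCC1`: > 1000000 nM
Compound 2 `COc1ccc(-c2noc(-c3ccc(F)cc3)n2)cc1OC1CCCC1`: > 1000000 nM

Of the compounds shown here, two have been tested in a functional assay on PC-3 cells (Homo sapiens) for antiproliferative activity, read by MTT assay, with a stated time of 24 h; on this read-out lower numbers stand for stronger inhibition and higher numbers for weaker inhibition. Compound 1 returns only a limit of the assay, > 1000000 nM, and no number. Compound 2 likewise returns only a limit, > 1000000 nM, so its standing on this assay is not a measured value but the top of what the assay reports. Among the measured compounds shown here, the single step between them, a step that the two limits leave unreadable from compound 1 to compound 2, cannot be sized because of the limit of > 1000000 nM in this assay, at which 2 of the 2 values shown sit.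

Compound 3 `COc1ccc(-c2noc(C3CCCN3)n2)cc1OC1CCCC1` differs from compound 2 by pyrrolidin-2-yl in place of 4-fluorophenyl on an aromatic carbon. For the measured compounds named here, no measured step bears on this change: the only recorded step is unreadable, and neither value shown gives a number from which a direction could be taken. With no readable reference, the size of any change in this assay cannot be anticipated from the data, and the most likely outcome is another limit. Compound 3 is therefore estimated at 1000000 nM, with a range from 100000 nM to 3000000 nM. The expected step, a number no higher from compound 2 to compound 3 (the limit leaves the size open), is an estimate only, not a reading.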

Compound 3, half-maximal inhibitory concentration: > 1000000 nM
Compound 3 ended at the assay's limit; the forecaster's own chance of this, stated with the estimate: 80%; the middle value sits exactly at the limit.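

Among the compounds shown here, no step among compound 1, compound 2 and compound 3 can be read in this assay, because all three stop at a limit of the assay and give no number: the limit of > 1000000 nM in this assay, at which 3 of the 3 values shown sit. The compounds shown leave open how 4-chlorophenyl, 4-fluorophenyl and pyrrolidin-2-yl on the shared core compare in this antiproliferative read-out.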